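Swapping acetyl for tert-butoxycarbonyl on a dodecyl chloromethyl ketone

The source may report more compounds than this note shows. Statements on the series, on what has been measured and on what is new or still open speak of the compounds shown alone.

Three chloromethyl ketones built on a cysteine-derived frame were tested in a functional assay on NALM-6 cells (Homo sapiens); a higher number here means a weaker inhibitor, a lower number a stronger inhibitor. Compound 1 `CC(=O)N[C@@H](CSC/C=C(\C)CC/C=C(\C)CCC=C(C)C)C(=O)CCl` carries a farnesyl-type thioether and an acetamido group; in this assay compound 1 gives 3000 nM. Compound 2 `CC(C)=CCC/C(C)=C/CC/C(C)=C/CSC[C@H](NC(=O)OC(C)(C)C)C(=O)CCl` keeps the same thioether but differs by tert-butoxy in place of methyl on a carbonyl carbon, and compound 2 gives 10700 nM. The step recorded was a 3.6-fold higher number from compound 1 to compound 2 (0.55 log units; beyond the scatter). Compound 3 `CCCCCCCCCCCCSC[C@H](NC(C)=O)C(=O)CCl` replaces the branched unsaturated thioether with a straight dodecyl thioether; compound 3 gives 2000 nM, and of the three it shows the lowest number, although its gap to compound 1 lies within the scatter, while its gap to compound 2 lies beyond it. How the core of compound 3 differs from the core of compound 1 is not broken down here.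

Compound 4 `CCCCCCCCCCCCSC[C@H](NC(=O)OC(C)(C)C)C(=O)CCl` has not yet been measured. It stands to compound 3 exactly as compound 2 stands to compound 1: the change is tert-butoxy in place of methyl on a carbonyl carbon, at a place described in the same words for both pairs, so it is the same change made on a different core. Within the data shown here, the only guide is the single earlier step, so one expects a step of about a 3.5-fold higher number from compound 3 to compound 4 (0.54 log units; beyond the scatter), resting on the earlier step of a 3.6-fold higher number from compound 1 to compound 2 (0.55 log units; beyond the scatter). Because compound 3 gives 2000 nM, compound 4 is expected to give about 7000 nM, with a range estimated from 3000 nM to 17000 nM.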

Compound 4, half-maximal inhibitory concentration: 15100 nM
For compound 4 the middle estimate is 2.2-fold (0.33 log units) below the measured one, and the stated range covers the measured number.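

In this assay, tert-butoxy in place of methyl on a carbonyl carbon again gives a weaker inhibitor on the dodecyl core, with a 7.6-fold higher number from compound 3 to compound 4 (0.88 log units; beyond the scatter), so the change points the same way on both cores shown. Among these compounds, the step on the dodecyl core looks larger, but the two steps cannot be told apart, and the change carries over from one core to the other as far as these four compounds can show: the same change on two cores in this assay, a 3.6-fold higher number (0.55 log units; beyond the scatter) from compound 1 to compound 2 and a 7.6-fold higher number (0.88 log units; beyond the scatter) from compound 3 to compound 4, 2.1-fold (0.33 log units) apart, within the scatter of two such steps What this does not show is that the core has no influence on the size of the step, or that the change would behave alike on any further core, since it rests on only two pairs in a single assay, and it says nothing about why the number rises.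

The compounds shown leave open how the step would look with other groups on that carbonyl carbon, such as ethoxy or benzyloxy, or with a free amine in place of the acetamido group. They also leave open whether the same change would hold on a thioether with a longer chain than dodecyl, or on a frame in which a carboxylic acid stands in place of the chloromethyl ketone.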